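Trading a Dichlorophenyl for a Cyanophenyl Group

This account rests on a few compounds, and the source may have more. Where it says the series, first, only, none or still open, it means among the compounds named here.

Of the compounds shown here, two sharing one core have been measured in a functional assay with Melanocortin receptor 4 (Homo sapiens) as the target, read by cAMP accumulation; a higher number here means that more compound is needed for the effect, a lower number that less compound is needed. Compound 1 `COc1ccc(-n2nc(Sc3ccc(Cl)cc3)cc(CC[C@@H](C)NC(=O)[C@H]3CNCC[C@@H]3c3ccc(C(F)(F)F)cc3)c2=O)cc1` gives only a limit in this assay, > 5000 nM, and no number. Going by the values given here, compound 2 `COc1ccc(-n2nc(Sc3ccc(Cl)cc3)cc(CC[C@@H](C)NC(=O)[C@H]3CCNC[C@@H]3c3ccc(Cl)cc3Cl)c2=O)cc1` is the sole compound with a number, 2400 nM, so it stands alone among the values shown. The other entry, that of compound 1, is a limit (the limit of > 5000 nM in this assay, at which 1 of the 2 values shown sits). Compound 3 `COc1ccc(-n2nc(Sc3ccc(Cl)cc3)cc(CC[C@@H](C)NC(=O)[C@H]3CCNC[C@@H]3c3ccc(C#N)cc3)c2=O)cc1` has not yet been measured. It differs from compound 2 in one place: 4-cyanophenyl in place of 2,4-dichlorophenyl on a saturated ring carbon. Among the compounds with values here, no measured step between compounds matches this change, so the expectation rests on compound 2 alone. A modest loss in this assay is expected, a 1.7-fold higher number from compound 2 to compound 3 (0.22 log units; within the scatter), with a fair chance that the assay reports only a limit. Compound 3 is therefore estimated at 4000 nM in this assay, within a range of 1200 nM to 12000 nM.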

Compound 3, half-maximal effective concentration: 120 nM
For compound 3 the middle estimate is 33-fold (1.52 log units) above the measured one; the whole stated range lies above it.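

Replacing 2,4-dichlorophenyl with 4-cyanophenyl on this saturated ring carbon, two ring bonds from the ring nitrogen, gives in this assay a 20-fold lower number from compound 2 to compound 3 (1.30 log units; beyond the scatter), so this position responds strongly to the aryl group it carries. The two groups match in heavy-atom count and each holds one six-membered aromatic ring, which places the change in the two chlorine atoms that leave and the nitrile, with its hydrogen-bond acceptor, that enters. Nothing measured here gives a cause for this gain.

Compound 1 gives only a limit, > 5000 nM, and the steps to it cannot be read. As far as these compounds go, whether the gain comes from losing the chlorine atoms or from gaining the nitrile stays open, as does how 4-chlorophenyl or a pyridyl ring would read at this carbon.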